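Aryl ketone exchange in the nitrophenol enone series

The source may report more compounds than this note shows. Statements on the series, on what has been measured and on what is new or still open speak of the compounds shown alone.

Compound 1 `O=C(/C(=C\c1ccc(O)c([N+](=O)[O-])c1)SCc1ccc(Br)cc1)c1c(F)c(F)c(F)c(F)c1F` is the reference point of the set. In a functional assay on DU-145 cells (Homo sapiens) for inhibition, read by trypan blue exclusion, with a stated time of 96 h (on this read-out higher numbers stand for weaker inhibition of growth and lower numbers for stronger inhibition of growth), compound 1 gives 10000 nM, level with compound 3 `O=C(/C(=C\c1ccc([N+](=O)[O-])c(O)c1)SCc1ccc(Br)cc1)c1c(F)c(F)c(F)c(F)c1F` at 10000 nM, the two together the lowest of three numbers; compound 2 `O=C(/C(=C\c1ccc(O)c([N+](=O)[O-])c1)S(=O)(=O)Cc1ccc(Br)cc1)c1c(F)c(F)c(F)c(F)c1F` gives 50000 nM. The measured steps are a 5.0-fold higher number from compound 1 to compound 2 (0.70 log units; beyond the scatter) and no change at the digits printed from compound 1 to compound 3 (within the scatter). Compound 4 `O=C(/C(=C\c1ccc(O)c([N+](=O)[O-])c1)SCc1ccc(Br)cc1)c1ccc(C(F)(F)F)cc1` differs from compound 1 at the carbonyl carbon: 4-(trifluoromethyl)phenyl in place of 2,3,4,5,6-pentafluorophenyl on a carbonyl carbon. Going by the values given here, neither measured step touches that position, so nothing among the measured compounds speaks directly to this change, and no step beyond the scatter is expected. Compound 4 is therefore estimated at 10000 nM, within 3000 nM to 40000 nM, which means an expected step of no change at the digits printed from compound 1 to compound 4 (within the scatter).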

Compound 4, concentration for 50% growth inhibition: 10000 nM
For compound 4 middle estimate and measured number coincide at the digits printed, and the stated range covers the measured number.
By their numbers in this assay, from the lowest: compounds 1, 3 and 4 (each within the scatter of the next); then compound 2.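

In this assay the carbonyl position now has its first reading: no change at the digits printed from compound 1 to compound 4 (within the scatter) with 4-(trifluoromethyl)phenyl in place of 2,3,4,5,6-pentafluorophenyl. For this pair, full ring fluorination is therefore not needed to hold the growth-inhibition number. Nothing available bears on why the two aryl groups read alike.

Going by these compounds, whether an unfluorinated phenyl, or a ring carrying an amine or a carboxylic acid, holds the same level stays open. Also open, on these data alone, is whether the sulfonyl step carries over to the 4-(trifluoromethyl)phenyl ketone.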